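The compounds below may be only part of what the source reports. "The series", "measured", "known", "first", "only" and "open" are said of these compounds alone.

Measured so far:
- compound 1 `COc1ccc(CCCCCCCCOc2ccc(C[S+]([O-])c3cccc(C(=O)O)c3)nc2/C=C/C(=O)O)cc1`: 167 nM
- compound 2 `COc1ccc(CCCCCCCCOc2ccc(C[S+]([O-])Cc3cccc(C(=O)O)c3)nc2/C=C/C(=O)O)cc1`: 240 nM
- compound 3 `COc1ccc(CCCCCCCCOc2ccc(CSCc3cccc(C(=O)O)c3)nc2CCC(=O)O)cc1`: 8 nM

In an assay on isolated protein for displacement of a labelled ligand from leukotriene B4 receptor 1 (Homo sapiens) (on this read-out higher numbers stand for weaker inhibition and lower numbers for stronger inhibition), compound 2 gives the highest of the three numbers; compound 1 lies nearest, and the step of a 1.4-fold higher number from compound 1 to compound 2 (0.16 log units; within the scatter) is within the scatter. Within the data shown here, compound 3, with a sulfide in place of the sulfoxide and a saturated chain in place of the propenoic acid, gives 8 nM, a far lower number, but no single-change step connects it to compound 2.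

Compound 4 `COc1ccc(CCCCCCCCOc2ccc(CSCc3ccccc3C(=O)O)nc2/C=C/C(=O)O)cc1` differs from compound 2 by a group of 11 heavy atoms (8 carbon, 2 oxygen, 1 sulfur; one six-membered aromatic ring of carbon only) in place of a group of 12 heavy atoms (8 carbon, 3 oxygen, 1 sulfur; one six-membered aromatic ring of carbon only), on a saturated chain carbon bound to an aromatic carbon. Among the measured compounds shown here, only the step from compound 1 to compound 2 bears on the carboxyl-bearing ring, and it was small. The sulfide is also found in compound 3, whose value is much lower, but that compound differs in a second place, so the share of the sulfide alone is not known. Compound 4 is therefore expected to give a lower number than compound 2, by an uncertain amount, as a 4.0-fold lower number from compound 2 to compound 4 (0.60 log units; beyond the scatter), with the estimate for compound 4 being 60 nM and a range from 15 nM to 300 nM.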

Compound 4, inhibition constant: 112 nM
The estimate for compound 4 lay 1.9-fold (0.27 log units) below the measured number; the range from low to high includes it.
By their numbers in this assay, from the lowest: compound 3; then compounds 4, 1 and 2 (each within the scatter of the next, the first and the last beyond it).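

In this assay the (2-carboxybenzyl)sulfanyl group gives a 2.1-fold lower number from compound 2 to compound 4 (0.33 log units; beyond the scatter) and so shows, unlike the earlier step on the sulfur, that a change at this place can move the number beyond the scatter, though only modestly. Set against the 3-carboxyphenyl sulfoxide, the same group gives a 1.5-fold lower number from compound 1 to compound 4 (0.17 log units; within the scatter) and stays within the scatter, so the gain holds only against compound 2. No measurement shown here accounts for either step.

Both steps alter the sulfur and the carboxyl-bearing ring together, so the share of the sulfide and the share of the moved carboxylic acid remain unseparated. From the compounds shown here alone, how a sulfone on this sulfur, or a tetrazole in place of the carboxylic acid, would read in this assay also stays open.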